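A few compounds are considered here, and "the series" means these few. Any claim that something is new, unique, unknown or untested is made for them only; others in the source may bear on it.

Measured in a functional assay on PA-1 cells (Homo sapiens) for antiproliferative activity, read by MTT assay, with a stated time of 48 h; a higher number here means a weaker inhibitor, a lower number a stronger inhibitor:
- Compound 1 `O=C1N(Cc2ccc(Br)cc2)c2ccc(F)cc2C1(O)Cc1nnn[nH]1`: > 100000 nM, a limit of the assay and not a number
- Compound 2 `CN1C(=O)C(O)(Cc2nnn[nH]2)c2cc(Cl)ccc21`: > 100000 nM, also a limit and not a number
- Compound 3 `CCN1C(=O)C(O)(Cc2nnn[nH]2)c2cc(Cl)ccc21`: 49500 nM

Compound 3 alone has a real number here. The rest of the picture is the limit of > 100000 nM in this assay, at which 2 of the 3 values shown sit.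

Compound 4 `O=C1N(Cc2ccc(Br)cc2)c2ccc(Cl)cc2C1(O)Cc1nnn[nH]1` puts 4-bromophenyl in place of methyl on a saturated chain carbon bound to an amide-type nitrogen in a ring, so that ethyl becomes 4-bromobenzyl: 4-bromophenyl in place of methyl on a saturated chain carbon bound to an amide-type nitrogen in a ring.

Going by the values given here, one measured step touches this same place: an at least 2.0-fold lower number from compound 2 to compound 3 (0.30 log units; that floor lies within the scatter). Among the compounds with values here, there, methyl replaces hydrogen, a much smaller change than the one in compound 4, so it is only a weak guide.

Compound 1 also carries 4-bromobenzyl and gives > 100000 nM, which is a limit of the assay.

On this thin evidence, no step beyond the scatter is expected in this assay, with a slight lean towards a higher number. The estimated change is a 1.2-fold higher number from compound 3 to compound 4 (0.08 log units; within the scatter). For compound 4 the expected value is 60000 nM, with an estimated range from 20000 nM to 100000 nM.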

Compound 4, half-maximal inhibitory concentration: 35800 nM
Estimate against measurement, compound 4: 1.7-fold (0.22 log units) above; measured number inside the range.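

In this assay, replacing ethyl with 4-bromobenzyl on the ring's amide-type nitrogen adds an aromatic ring and a bromine, yet the result stays within the scatter: a 1.4-fold lower number from compound 3 to compound 4 (0.14 log units; within the scatter). Two further comparisons do go beyond the scatter, with 4-bromophenyl in place of hydrogen on the saturated chain carbon giving an at least 2.7-fold lower number from compound 2 to compound 4 (0.44 log units; beyond the scatter) and, with 4-bromobenzyl held fixed, chloro in place of fluoro on an aromatic carbon giving an at least 2.7-fold lower number from compound 1 to compound 4 (0.44 log units; beyond the scatter), which shows that a change away from this chain can also matter. These two steps give only minimum sizes, since each starts from a compound whose value is not a true number: the limit of > 100000 nM in this assay, at which 2 of the 4 values shown sit.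

The compounds shown cannot separate the contribution of the bromine from that of the aromatic ring, and an unsubstituted benzyl group would be needed to do so. Going by these compounds, it also remains open how a longer chain such as propyl, or a chain ending in an amine, would compare with ethyl and 4-bromobenzyl at this position.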